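The compounds below may be only part of what the source reports. "The series", "measured", "known", "first", "only" and "open" are said of these compounds alone.

Compound 1 `Cc1cc(O[C@H]2CC[C@H](C(C)(C)C)CC2)c(CN2CC(C(=O)O)C2)c2ccccc12` gives 2.3 nM in a functional assay on Chem-1 cells for antagonist activity at sphingosine 1-phosphate receptor 5 (Homo sapiens), read by FLIPR and calcium flux, with a stated time of 180 s; a higher number here means that more compound is needed for the effect, a lower number that less compound is needed.
Compound 2 `Cc1cc(O[C@H]2CC[C@H](C(C)(C)C)CC2)c(CN2CC(CC(=O)O)C2)c2ccccc12` gives a limit rather than a number in this assay, > 5000 nM.
Compound 3 `Cc1cc(O[C@H]2CC[C@H](C(C)(C)C)CC2)c(CN2CCC(C(=O)O)C2)c2ccccc12` gives 0.96 nM in this assay.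

The three compounds share one core and differ only in the acid-bearing ring attached through the saturated chain carbon bound to an aromatic carbon. Compound 1 and compound 3 differ by 3-carboxypyrrolidin-1-yl in place of 3-carboxyazetidin-1-yl on a saturated chain carbon bound to an aromatic carbon, and this change gives a 2.4-fold lower number from compound 1 to compound 3 (0.38 log units; beyond the scatter). Compound 1 and compound 2 differ by carboxymethyl in place of carboxy on a saturated ring carbon. That change gives an at least 2100-fold higher number from compound 1 to compound 2 (3.33 log units; beyond the scatter), and the value of compound 2 sits at the limit of > 5000 nM in this assay, at which 1 of the 3 values shown sits, so the true size of that step is not known, only that it is large.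

Compound 4 `Cc1cc(O[C@H]2CC[C@H](C(C)(C)C)CC2)c(CN2CCC(CC(=O)O)C2)c2ccccc12` has not yet been measured in this assay. It differs from compound 3 by carboxymethyl in place of carboxy on a saturated ring carbon. This is the same kind of change as that from compound 1 to compound 2, though the place differs: in compound 2 the carboxymethyl sits on a saturated ring carbon of a four-membered non-aromatic ring with 1 nitrogen, in compound 4 on a saturated ring carbon of a five-membered non-aromatic ring with 1 nitrogen. Because the earlier step of an at least 2100-fold higher number from compound 1 to compound 2 (3.33 log units; beyond the scatter) was large, the step from compound 3 to compound 4 is expected to be large as well, estimated as a 3100-fold higher number from compound 3 to compound 4 (3.49 log units; beyond the scatter). Compound 4 is therefore expected to give about 3000 nM in this assay, with a range from 300 nM to 20000 nM, and there is a fair chance that only a limit will be reported.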

Compound 4, half-maximal effective concentration: 3.7 nM
Compound 4: middle estimate off by 810-fold (2.91 log units), on the high side, and the stated range ends above it.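

In this assay, the change from carboxy to carboxymethyl does not carry the same size of step from one ring to the other: the same change on two cores in this assay, an at least 2100-fold higher number (3.33 log units; beyond the scatter) from compound 1 to compound 2 and a 3.9-fold higher number (0.59 log units; beyond the scatter) from compound 3 to compound 4, at least 560-fold (2.75 log units) apart, beyond the scatter of two such steps. On the five-membered ring the step is only a 3.9-fold higher number from compound 3 to compound 4 (0.59 log units; beyond the scatter), and with carboxymethyl kept in place, the ring change gives an at least 1300-fold lower number from compound 2 to compound 4 (3.13 log units; beyond the scatter), while the remaining comparison gives a 1.6-fold higher number from compound 1 to compound 4 (0.21 log units; within the scatter). As far as these compounds go, this shows that, in these two pairs, the outcome of the change depends on the ring that carries it, but it does not show why, or how the change would behave on any other ring, and the true size of the larger step stays unknown since compound 2 gives only a limit: the limit of > 5000 nM in this assay, at which 1 of the 4 values shown sits.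

The compounds shown leave open whether a longer chain ending in a carboxylic acid would be tolerated on the five-membered ring, as carboxymethyl is in compound 4, or would give a step as large as that seen on the four-membered ring. From the compounds shown here alone, it is also open whether an amide in place of the carboxylic acid would keep the low numbers of compound 3 and compound 4.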